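The source may report more compounds than this note shows. Statements on the series, on what has been measured and on what is new or still open speak of the compounds shown alone.

Measured so far in an assay on isolated protein for inhibition of malate dehydrogenase, mitochondrial (Sus scrofa), with stated times of 45 min and 30 min; a lower number here means a stronger inhibitor, a higher number a weaker inhibitor:
Compound 1 `Cc1ccccc1S(=O)(=O)Nc1ccc2oc(-c3ccccc3)nc2c1` gives > 63000 nM in this assay, which is a limit of the assay and not a number.
Compound 2 `COc1cccc(S(=O)(=O)Nc2ccc3oc(-c4ccccc4)nc3c2)c1` gives > 63000 nM in this assay, again only a limit.
Compound 3 `COc1cccc(S(=O)(=O)Nc2ccc(-c3nc4ccccc4o3)cc2)c1` gives > 63000 nM in this assay, also only a limit.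

Compound 1 and compound 2 share one core. Compound 3 is built from the same atoms as compound 2, joined differently, and the difference between the two cores is not broken down here. The change from compound 2 to compound 1 is 2-methylphenyl in place of 3-methoxyphenyl on a sulfonyl sulfur, and the step that the two limits leave unreadable from compound 2 to compound 1 cannot be sized, because all three values sit at the limit of > 63000 nM in this assay, at which 3 of the 3 values shown sit.

Compound 4 `Cc1ccccc1S(=O)(=O)Nc1ccc(-c2nc3ccccc3o2)cc1` has not yet been measured in this assay. It differs from compound 3 by 2-methylphenyl in place of 3-methoxyphenyl on a sulfonyl sulfur, the same change already seen from compound 2 to compound 1. Since compound 3 gives only a limit, and the same change left both compound 2 and compound 1 at a limit, compound 4 is expected to remain at the limit as well, with an expected step that the limit leaves unreadable from compound 3 to compound 4. The estimate for compound 4 is 100000 nM, expected to fall between 40000 nM and 300000 nM.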

Compound 4, half-maximal inhibitory concentration: > 63000 nM
Compound 4 was reported as a limit; the forecaster's own chance of this, stated with the estimate: 85%; the middle value is on the limit's open side.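

In this assay compound 4 gives > 63000 nM, which is a limit and not a number. No size can be read for the change from compound 3 to compound 4, because both compounds sit at the same limit: the limit of > 63000 nM in this assay, at which 4 of the 4 values shown sit.

The compounds shown leave open whether the two cores or the two sulfonyl groups differ in inhibition at all.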